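Fluoro for ethyl on a fused-ring quinoline amide series

A few compounds are considered here, and "the series" means these few. Any claim that something is new, unique, unknown or untested is made for them only; others in the source may bear on it.

Measured compounds:
compound 1, `Cc1c(C(=O)Nc2c(F)cc(-c3cccc(F)c3)cc2F)nc2ccc(F)cc2c1O`, 2.34%
compound 2, `Cc1ccc2nc(C(=O)Nc3c(F)cc(-c4cccc(F)c4)cc3F)c(C)c(C(=O)O)c2c1`, 3.65%
compound 3, `CCc1ccc2nc(C(=O)Nc3c(F)cc(-c4cccc(F)c4)cc3F)c(C)c(C(=O)O)c2c1`, 17.7%

In a functional assay on A-375 cells (Homo sapiens) for antiproliferative activity, read by MTT assay, with a stated time of 24 h, tested at 1.23 ug/mL (on this read-out higher numbers stand for a stronger effect at the one concentration tested and lower numbers for a weaker effect), compound 3 stands highest of the three numbers; compound 2 is nearest, and compound 1 furthest, both beyond the scatter. For the measured compounds named here, the one measured step that touches this position is a number 14.1 percentage points higher from compound 2 to compound 3 (beyond the scatter), which shows a modest gain when the chain grows by one carbon. Compound 4, `Cc1c(C(=O)Nc2c(F)cc(-c3cccc(F)c3)cc2F)nc2ccc(F)cc2c1C(=O)O`, differs from compound 3 by fluoro in place of ethyl on an aromatic carbon; the ethyl group that carried the gain leaves and a single fluorine atom enters in its place. Compound 1, which also bears a fluoro group on its fused ring, gives 2.34% in this assay, a number close to that of compound 2. Going by the values given here, with the only favourable step tied to the longer chain, compound 4 is expected to fall back toward the values of compounds 1 and 2, a step of a number 13.7 percentage points lower from compound 3 to compound 4 (beyond the scatter). Compound 4 is therefore estimated at 4%, within a range of 0% to 13%.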

Compound 4, a percentage reported as inhibition, at one concentration (the size of the read-out at that concentration, not a potency): 16.3%
Beside the measured number, compound 4's estimate is 12.3 percentage points below it, and the stated range ends below it.
By their numbers in this assay, from the lowest: compounds 1 and 2 (each within the scatter of the next); then compounds 4 and 3 (each within the scatter of the next).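

In this assay, the step of a number 1.4 percentage points lower from compound 3 to compound 4 (within the scatter) shows that fluoro in place of ethyl on this aromatic carbon leaves the two numbers indistinguishable, so the gain seen with ethyl is not unique to that group among the groups tested here. The step of a number 12.7 percentage points higher from compound 2 to compound 4 (beyond the scatter) for fluoro in place of methyl shows that this position can separate two small groups, and the step of a number 14 percentage points higher from compound 1 to compound 4 (beyond the scatter) adds that, with fluoro held in place, carboxy in place of hydroxy on an aromatic carbon also moves the number. Nothing measured here explains these steps.

Going by these compounds, it remains open how a chloro group, a methoxy group or a longer chain would read at this aromatic carbon. An amide or an ester in place of the carboxylic acid also remains untested among the compounds shown.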